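Removing the Fluorophenyl Ring from Compound 1

The compounds below may be only part of what the source reports. "The series", "measured", "known", "first", "only" and "open" are said of these compounds alone.

Of the compounds shown here, three have been measured so far. In an ADME assay on microsomes from liver (Rattus norvegicus) for metabolic stability, using NADPH, with a stated time of 10 min (a higher number here means that more of the compound is left, a lower number that less of the compound is left), compound 1 `CCCCc1nc(=O)c(S(=O)(=O)c2ccc(-c3ccc(F)cc3)cc2)c(O)n1-c1c(OC)cccc1OC` gives 5%. Compound 2 `CCCCc1[nH]c(=O)c(S(=O)(=O)c2ccc(-c3ccncc3C)cc2)c(O)c1-c1c(OC)cccc1OC` gives 57% in this assay, and compound 3 `COc1cccc(OC)c1-n1c(COC(C)C)nc(=O)c(S(=O)(=O)c2ccc(-c3ccc(F)nc3)cc2)c1O` gives 30%. Compound 1 therefore stands lowest of the three numbers: its nearest neighbour is compound 3, whose number lies higher by a margin beyond the usual scatter, and compound 2 lies further above it still. No two of these compounds differ in only one place, so no single step can be read from them.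

Compound 4 `CCCCc1nc(=O)c(S(=O)(=O)c2ccccc2)c(O)n1-c1c(OC)cccc1OC` has not yet been measured. It differs from compound 1 by hydrogen in place of 4-fluorophenyl on an aromatic carbon, para to a large group. Among the measured compounds shown here, no measured pair shows what this change does. Starting from the low number of compound 1 in this assay, a small upward step is expected, a number 10 percentage points higher from compound 1 to compound 4 (within the scatter), one that may not exceed the scatter. Compound 4 is estimated at 15% in this assay, with a range from 3% to 40%.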

Compound 4, percent of the compound remaining: 93%
For compound 4 the middle estimate is 78 percentage points below the measured one, outside the stated range (above it).
By their numbers in this assay, from the lowest: compound 1; then compound 3; then compound 2; then compound 4.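

Hydrogen in place of 4-fluorophenyl on this aromatic carbon, para to a large group, gives in this assay a number 88 percentage points higher from compound 1 to compound 4 (beyond the scatter). This position therefore has a large effect on the read-out, at least in the setting of compound 1. Among the compounds shown here, none of the earlier compounds differed in only one place, so this is the first single change that can be read, and nothing measured here accounts for the size of the step.

As far as these compounds go, it remains open whether the whole ring or only its fluorine matters: a plain phenyl, a methyl or an amine at this position could fall anywhere between compound 1 and compound 4. From the compounds shown here alone, it is also open whether hydrogen in place of the ring carried by compound 2 or compound 3 would give a step of similar size.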